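Trimethoxyphenyl benzimidazoles: swapping the pendant aryl group

The source may report more compounds than this note shows. Statements on the series, on what has been measured and on what is new or still open speak of the compounds shown alone.

Measured compounds:
Compound 1, `COc1cc(-n2cnc3ccc(-c4cccc(N)c4)cc32)cc(OC)c1OC`, gives 640 nM in a functional assay on A549 cells (Homo sapiens) for antiproliferative activity, read by MTT assay, with a stated time of 72 h; on this read-out lower numbers stand for stronger inhibition and higher numbers for weaker inhibition.
Compound 2, `COc1cc(-n2cnc3ccc(-c4ccc([N+](=O)[O-])cc4)cc32)cc(OC)c1OC`, gives 8940 nM in this assay.
Compound 3, `COc1cc(-n2cnc3ccc(-c4cccc(C)c4C)cc32)cc(OC)c1OC`, gives 9250 nM in this assay.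

On these numbers compound 2 stands second highest of the three: its step to compound 3 is a 1.0-fold higher number from compound 2 to compound 3 (0.01 log units; within the scatter), within the scatter, while its step from compound 1 is a 14-fold higher number from compound 1 to compound 2 (1.15 log units; beyond the scatter), a large rise.

Compound 4, `COc1ccccc1-c1ccc2ncn(-c3cc(OC)c(OC)c(OC)c3)c2c1`, differs from compound 2 as follows: 2-methoxyphenyl in place of 4-nitrophenyl on an aromatic carbon. Within the data shown here, the steps that bear on this are a 14-fold higher number from compound 1 to compound 2 (1.15 log units; beyond the scatter) and a 14-fold higher number from compound 1 to compound 3 (1.16 log units; beyond the scatter), both large; together with a 1.0-fold higher number from compound 2 to compound 3 (0.01 log units; within the scatter) they show that only the 3-aminophenyl gave a low number, and two other aryl groups sat close together. Nothing measured covers a 2-methoxyphenyl, so no step beyond the scatter is expected in this assay, perhaps a slight fall.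

For compound 4 the estimate is 6000 nM, from 1500 nM to 20000 nM, an expected step of a 1.5-fold lower number from compound 2 to compound 4 (0.17 log units; within the scatter).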

Compound 4, half-maximal inhibitory concentration: 4320 nM
The estimate for compound 4 lay 1.4-fold (0.14 log units) above the measured number; the range from low to high includes it.
By their numbers in this assay, from the lowest: compound 1; then compound 4; then compounds 2 and 3 (each within the scatter of the next).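

In this assay, the 2-methoxyphenyl group gives a modestly lower number than either the 4-nitrophenyl group (a 2.1-fold lower number from compound 2 to compound 4 (0.32 log units; beyond the scatter)) or the 2,3-dimethylphenyl group (a 2.1-fold lower number from compound 3 to compound 4 (0.33 log units; beyond the scatter)), so aryl groups other than 3-aminophenyl need not all sit at the same high level. It still falls short of the 3-aminophenyl group (a 6.8-fold higher number from compound 1 to compound 4 (0.83 log units; beyond the scatter)), which keeps the lowest number of the four. Nothing available explains these differences.

Going by these compounds, it remains open whether a 4-aminophenyl or 3-hydroxyphenyl group at this position would match compound 1.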